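A few compounds are considered here, and "the series" means these few. Any claim that something is new, unique, unknown or untested is made for them only; others in the source may bear on it.

Within the data shown here, compound 1 `Cc1nc2c3ccccc3ccc2c2nc3c(ccc4ccccc43)c(-c3cccc([N+](=O)[O-])c3)c12` gives 13200 nM in a functional assay on HCT-116 cells (Homo sapiens) for cytotoxicity, read by MTT assay, with a stated time of 48 h (a higher number here means a weaker inhibitor, a lower number a stronger inhibitor), the lowest of the three numbers known here. Compound 3 `Cc1nc2c3ccccc3ccc2c2nc3c(ccc4ccccc43)c(-c3cccc4ccccc34)c12` gives 20800 nM, and compound 2 `Cc1nc2c3ccccc3ccc2c2nc3c(ccc4ccccc43)c(-c3cccnc3)c12` gives 34200 nM. Compound 4 `Cc1nc2c3ccccc3ccc2c2nc3c(ccc4ccccc43)c(-c3ccccc3Cl)c12` differs from compound 1 by 2-chlorophenyl in place of 3-nitrophenyl on an aromatic carbon. The two measured steps that also swap out the 3-nitrophenyl bear on this: a 1.6-fold higher number from compound 1 to compound 3 (0.20 log units; within the scatter), and a 2.6-fold higher number from compound 1 to compound 2 (0.41 log units; beyond the scatter). Both replacements at the same aromatic carbon gave higher numbers, one within the scatter and one modest. A similar small shift upward, or no step beyond the scatter, is therefore expected for compound 4, that is a 1.2-fold higher number from compound 1 to compound 4 (0.08 log units; within the scatter). The value expected for compound 4 is 16000 nM, with a range from 6500 nM to 40000 nM.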

Compound 4, half-maximal inhibitory concentration: 48200 nM
Estimate against measurement, compound 4: 3.0-fold (0.48 log units) below; measured number above the stated range.
By their numbers in this assay, from the lowest: compounds 1, 3, 2 and 4 (each within the scatter of the next, the first and the last beyond it).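

At this aromatic carbon, keeping a carbon-only six-membered ring does not hold the number of compound 1 in this assay: 2-chlorophenyl in place of 3-nitrophenyl gives a step beyond the scatter (a 3.7-fold higher number from compound 1 to compound 4 (0.56 log units; beyond the scatter)). The same holds against naphthalen-1-yl (a 2.3-fold higher number from compound 3 to compound 4 (0.36 log units; beyond the scatter)), whereas pyridin-3-yl shows only a 1.4-fold higher number from compound 2 to compound 4 (0.15 log units; within the scatter). No measurement here accounts for these steps. Still open, on these data alone, is whether the chlorine itself or its place on the ring matters, which 3-chlorophenyl could separate, and how a phenyl ring carrying an amine or a carboxylic acid would compare.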